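Chain branching and adenosine A3 displacement: series notes

The source may hold more compounds than are shown below. What is called first, only, known or untested is meant among the compounds shown, and "the series" means these compounds.

Compound 1 `CCCOC(=O)C1=C(C)NC(=S)NC1c1ccco1` and compound 2 `CC1=C(C(=O)OCC(C)C)C(c2ccco2)NC(=S)N1` share one core; compound 3 `CCCC(=O)C1=C(C)NC(=O)NC1c1ccco1` and compound 4 `CC1=C(C(=O)CC(C)C)C(c2ccco2)NC(=O)N1` share another. In an assay on membranes from HeLa cells for displacement of a labelled ligand from adenosine receptor A3 (Homo sapiens), read by scintillation counting, with a stated time of 180 min, tested at 1 uM (on this read-out higher numbers stand for more inhibition at the one concentration tested (going by the name of the read-out) and lower numbers for less inhibition), compound 1 gives 1%, and compound 2 gives 10%. The change methyl in place of hydrogen on a saturated chain carbon bound to two saturated chain carbons thus made a step of a number 9 percentage points higher from compound 1 to compound 2 (within the scatter). In this assay compound 3 gives 1%, level with compound 1 at the digits given. How the two cores differ is not broken down here. Compound 4 carries the same change as compound 2, (methyl in place of hydrogen on a saturated chain carbon bound to two saturated chain carbons), and the place of the change reads the same in both pairs. Because a number 9 percentage points higher from compound 1 to compound 2 (within the scatter) is within the scatter, the step from compound 3 to compound 4 is expected to be small, about a number 4 percentage points higher from compound 3 to compound 4 (within the scatter). Compound 4 is therefore estimated at 5% in this assay, with a range from -5% to 15%.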

Compound 4, a percentage reported as inhibition, at one concentration (the size of the read-out at that concentration, not a potency): 31%
Estimate against measurement, compound 4: 26 percentage points below; measured number outside the range, above it.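

In this assay the methyl in place of hydrogen gives a number 30 percentage points higher from compound 3 to compound 4 (beyond the scatter) on the core of compound 3, and the isobutylcarbonyl chain of compound 4 thus separates from the propylcarbonyl chain beyond the scatter. The change does not carry from one core to the other at the same size: the same change on two cores in this assay, a number 9 percentage points higher (within the scatter) from compound 1 to compound 2 and a number 30 percentage points higher (beyond the scatter) from compound 3 to compound 4, 21 percentage points apart, beyond the scatter of two such steps. This shows a core-dependent step size for these two pairs only; it does not show which feature of the cores sets the size, and two pairs give no rule for a further core.

Open, on these data alone, is whether a longer chain, such as pentyl, or a cyclohexyl group in the same place would extend the step on either core. As far as these compounds go, an amine at the end of the chain is likewise open.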